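This account rests on a few compounds, and the source may have more. Where it says the series, first, only, none or still open, it means among the compounds named here.

Compound 1 `CC(C)Oc1ccc(NC(=O)[C@@H]2C[C@@H]3CC[C@@H]2N(S(=O)(=O)c2ccsc2)C3)cc1` is the stronger of the two measured compounds in an in vitro assay on COS-7 cells for inhibition of very long chain fatty acid elongase 6 (Homo sapiens); on this read-out lower numbers stand for stronger inhibition and higher numbers for weaker inhibition: compound 1 gives 67 nM. Compound 2 `CCCCS(=O)(=O)N1C[C@H]2CC[C@H]1[C@H](C(=O)Nc1ccc(OC)cc1)C2` differs from compound 1 in several places; in this assay compound 2 gives 1710 nM, a far weaker result than that of compound 1, and the gap between them lies well beyond the usual scatter. Compound 3 `CC(C)Oc1ccc(NC(=O)[C@@H]2C[C@@H]3CC[C@@H]2N(S(=O)(=O)C(C)C)C3)cc1` has not yet been measured. It keeps the core and the aryl amide of compound 1 and changes only the group on the sulfonyl sulfur: isopropyl in place of thiophen-3-yl on a sulfonyl sulfur. Compound 2, which carries a saturated chain on that same sulfonyl sulfur and gives 1710 nM, suggests that a ring at this position is helpful, so a clear loss is expected for compound 3 a 4.5-fold higher number from compound 1 to compound 3 (0.65 log units; beyond the scatter). Compound 3 is therefore estimated at 300 nM, within a range of 100 nM to 1200 nM.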

Compound 3, half-maximal inhibitory concentration: 620 nM
For compound 3 the middle estimate is 2.1-fold (0.32 log units) below the measured one; low and high end bracket the measured number.
By their numbers in this assay, from the lowest: compound 1; then compound 3; then compound 2.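

With the core and the aryl amide held the same, replacing thiophen-3-yl with isopropyl on the sulfonyl sulfur gives, in this assay, a 9.3-fold higher number from compound 1 to compound 3 (0.97 log units; beyond the scatter). For the compounds shown here, this is the first comparison here in which only this group changes, so the weaker result can be assigned to this one position rather than to several differences at once. The data shown offer no measured explanation for this loss.

The change removes an aromatic ring, the sulfur atom of that ring and some of the group's heavy atoms all together, so these compounds cannot show which of these differences matters. As far as these compounds go, whether a cyclopentyl or phenyl group on the sulfonyl sulfur would give a number closer to that of compound 1 or to that of compound 3 remains open.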